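Hydrazone variation on a shared chloropyrimidine core

A few compounds are considered here, and "the series" means these few. Any claim that something is new, unique, unknown or untested is made for them only; others in the source may bear on it.

Of the compounds shown here, three have been tested in an ADME assay on HT-29 cells (Homo sapiens) for inhibition, read by MTT assay, with a stated time of 72 h; on this read-out higher numbers stand for weaker inhibition and lower numbers for stronger inhibition. Compound 1 `C=CC(=O)Nc1cccc(Nc2nc(N/N=C/c3cn(Cc4ccccc4)c4ccccc34)ncc2Cl)c1` gives 11000 nM in this assay. Compound 2 `C=CC(=O)Nc1cccc(Nc2nc(N/N=C(\C)c3ccc(F)cc3F)ncc2Cl)c1` gives 4360 nM in this assay. Compound 3 `COc1ccc(/C=N/Nc2ncc(Cl)c(Nc3cccc(NC(=O)/C=C/CN(C)C)c3)n2)cc1` gives 4820 nM in this assay. Among these three numbers compound 3 holds the second highest value; its nearest neighbour is compound 2, whose value lies within the scatter of repeated measurements, so no order between compound 2 and compound 3 can be stated, while compound 1 shows a higher number than compound 3 that does lie beyond the scatter.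

The step that follows leads to compound 4 `C/C(=N\Nc1ncc(Cl)c(Nc2cccc(NC(=O)/C=C/CN(C)C)c2)n1)c1ccccn1`, which has not yet been measured. It differs from compound 3 in one place: a group of 9 heavy atoms (7 carbon, 2 nitrogen; one six-membered aromatic ring with 1 hetero atom) in place of a group of 10 heavy atoms (8 carbon, 1 nitrogen, 1 oxygen; one six-membered aromatic ring of carbon only), on a nitrogen on an aromatic ring. Among the compounds with values here, no pair of measured compounds in this set differs in a single place, so no measured step can serve as a direct guide for this change.

Compound 4 is expected to stay close to compound 3, with a step of a 1.1-fold lower number from compound 3 to compound 4 (0.03 log units; within the scatter) that is estimated to remain inside the usual scatter, in either direction, since compound 2 with 4360 nM and compound 3 with 4820 nM show that different groups on this nitrogen can give like numbers. On that basis compound 4 is expected to give about 4500 nM in this assay, within a range from 1500 nM to 13000 nM.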

Compound 4, half-maximal inhibitory concentration: 120 nM
Beside the measured number, compound 4's estimate is 38-fold (1.57 log units) above it; the measured number lies below the stated range.
By their numbers in this assay, from the lowest: compound 4; then compounds 2 and 3 (each within the scatter of the next); then compound 1.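

In this assay, the exchange of groups on a nitrogen on an aromatic ring brings a 40-fold lower number from compound 3 to compound 4 (1.60 log units; beyond the scatter), a large step that shows this position is far from indifferent to the group it carries. Within the data shown here, this is the first measured step in the set that changes one place only, and it shows that replacing a six-membered aromatic ring of carbon only with one holding a hetero atom, within a group that also loses its oxygen, can go with a much lower number on the shared core. Nothing given here bears on why the number falls so far.

The change alters the ring and the rest of the group at once, so the compounds shown do not tell which part of it accounts for the step. On these data alone, it remains open how a plain phenyl ring or a pyrazine ring would stand in this same place, and whether the step would hold with the acrylamide chain of compound 2 in place of the dimethylamino-bearing chain of compound 4.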